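The compounds below may be only part of what the source reports. "The series", "measured", "known", "first", "only" and "open" are said of these compounds alone.

Measured so far:
- compound 1 `CNC1=CC(=O)c2c(cnc(C)c2C)C1=O`: 18000 nM
- compound 2 `CNC1=CC(=O)c2cc(C)ncc2C1=O`: 2230 nM

Both were tested in a functional assay on UXF 1138L cells (Homo sapiens) for cytotoxicity, read by propidium iodide staining, with a stated time of 4 days; a lower number here means a stronger inhibitor, a higher number a weaker inhibitor. Compound 2 holds the lower of the two numbers; the step of an 8.1-fold lower number from compound 1 to compound 2 (0.91 log units; beyond the scatter) is the only one recorded in the series, and it concerns an aromatic carbon, not the amine nitrogen.

Compound 3 `Cc1cc2c(cn1)C(=O)C(NCl)=CC2=O` is not yet measured. It differs from compound 2 by chloro in place of methyl on an amine nitrogen. For the measured compounds named here, no measured step touches this nitrogen, so the one recorded step gives no direct guide to the size or direction of the change; the exchange of one heavy atom for another with no change in donor or acceptor count suggests nothing that would force a large move. The expected step of a 1.1-fold higher number from compound 2 to compound 3 (0.05 log units; within the scatter) is therefore small, with wide uncertainty in either direction.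

Compound 3 is estimated at 2500 nM in this assay, with a range from 600 nM to 10000 nM.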

Compound 3, half-maximal inhibitory concentration: 1680 nM
Beside the measured number, compound 3's estimate is 1.5-fold (0.17 log units) above it, and the stated range covers the measured number.
By their numbers in this assay, from the lowest: compounds 3 and 2 (each within the scatter of the next); then compound 1.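

Chloro in place of methyl on an amine nitrogen gives a 1.3-fold lower number from compound 2 to compound 3 (0.12 log units; within the scatter) in this assay and this is the only measured step at this nitrogen among the compounds shown. Compound 2 and compound 3 therefore cannot be told apart here, so at this position the exchange of one group for the other produces no change that stands clear of the scatter. No measurement on hand bears on this result.

Only methyl and chloro are shown on this nitrogen, so it remains open how a plain hydrogen, a hydroxyl or a longer chain would read there. Also open, going by these compounds, is whether the step seen on the aromatic carbon would hold with chloro on the nitrogen.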